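The source may report more compounds than this note shows. Statements on the series, on what has been measured and on what is new or still open speak of the compounds shown alone.

Of the compounds shown here, three have so far been tested in a functional assay on DU-145 cells (Homo sapiens) for inhibition, read by trypan blue exclusion, with a stated time of 96 h; a higher number here means a weaker inhibitor of growth, a lower number a stronger inhibitor of growth. Compound 3 `O=C(/C(=C\c1ccc(O)cc1)SCc1ccc(Cl)cc1)c1ccc(Cl)cc1` gives 10000 nM in this assay, and compound 1 `O=C(/C(=C\c1ccc(O)cc1)SCc1ccc(Cl)cc1)c1ccc(Br)cc1` gives 10000 nM. The change leading from compound 3 to compound 1 is bromo in place of chloro on an aromatic carbon, and the measured step is no change at the digits printed from compound 3 to compound 1 (within the scatter).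

Compound 2 `O=C(/C(=C\c1c(O)cc(O)cc1O)Sc1ccccc1Br)c1ccc(Cl)cc1` carries a different core from compound 3; the difference between the two cores is not broken down here. For compound 2 this assay reports only a limit, > 100000 nM. That reading sits at the limit of > 100000 nM in this assay, at which 1 of the 3 values shown sits.

Compound 4 `O=C(/C(=C\c1c(O)cc(O)cc1O)Sc1ccccc1Br)c1ccc(Br)cc1` has not yet been measured in this assay. It differs from compound 2 by the same change that separates compound 3 from compound 1, namely bromo in place of chloro on an aromatic carbon, at the same place in both pairs. The step is expected to be a number no higher from compound 2 to compound 4 (the limit leaves the size open), set beside the measured no change at the digits printed from compound 3 to compound 1 (within the scatter), which lies within the scatter. This expectation rests on that measured step and on compound 2 standing at the limit of this assay, so that the same small change is not expected to bring compound 4 into the measurable range. Compound 4 is therefore expected to give 100000 nM in this assay, somewhere between 50000 nM and 300000 nM, most probably again reported only as a limit.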

Compound 4, concentration for 50% growth inhibition: > 100000 nM
Compound 4 gave a limit, no number (the forecaster's own chance of this, stated with the estimate: 80%); the middle value lies on the limit itself.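

In this assay compound 4 gives > 100000 nM, which is a limit and not a number. Compound 2 also stands at a limit, so no step can be read for the change from chloro to bromo between compound 2 and compound 4: the limit of > 100000 nM in this assay, at which 2 of the 4 values shown sit. The compounds shown leave open whether this change has any effect on the core shared by compound 2 and compound 4.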